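Thioether Ring Exchange on a Shared Amide Core

This account rests on a few compounds, and the source may have more. Where it says the series, first, only, none or still open, it means among the compounds named here.

Compound 3 `Cn1cnnc1SCC(=O)Nc1ccc(-c2nc(-c3ccccc3)c(-c3ccccc3)n2C)cc1` carries the highest of the three numbers in a functional assay on HT-29 cells (Homo sapiens) for cytotoxicity, read by MTT assay, with a stated time of 24 h, tested at 32 ug/mL (a higher number here means a stronger effect of the compound at the concentration tested, a lower number a weaker effect), where compound 3 gives 86.1%. Compound 2 `Cn1c(-c2ccc(NC(=O)CSc3nc4ccccc4o3)cc2)nc(-c2ccccc2)c1-c1ccccc1` gives 79.3% and compound 1 `Cn1c(-c2ccc(NC(=O)CCl)cc2)nc(-c2ccccc2)c1-c1ccccc1` gives 53.2%; the step of a number 6.8 percentage points higher from compound 2 to compound 3 (within the scatter) stays within the scatter, while a number 26.1 percentage points higher from compound 1 to compound 2 (beyond the scatter) and a number 32.9 percentage points higher from compound 1 to compound 3 (beyond the scatter) go beyond it. Compound 4 `Cn1c(-c2ccc(NC(=O)CSC3=NCCS3)cc2)nc(-c2ccccc2)c1-c1ccccc1` differs from compound 3 by a group of 5 heavy atoms (3 carbon, 1 nitrogen, 1 sulfur; one five-membered non-aromatic ring with 2 hetero atoms) in place of a group of 6 heavy atoms (3 carbon, 3 nitrogen; one five-membered aromatic ring with 3 hetero atoms), on a sulfur. Within the data shown here, the one measured step at the same sulfur, a number 6.8 percentage points higher from compound 2 to compound 3 (within the scatter), was within the scatter, and both sulfur-linked rings sit far above the chloro compound 1, so only a small step in this assay is expected, in either direction or none beyond the scatter. Compound 4 is therefore estimated at 78%, within 60% to 92%, an expected step of a number 8.1 percentage points lower from compound 3 to compound 4 (within the scatter).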

Compound 4, a percentage reported as activity, at one concentration (the size of the read-out at that concentration, not a potency): 59.4%
Estimate against measurement, compound 4: 18.6 percentage points above; the measured number lies below the stated range.
By their numbers in this assay, from the lowest: compounds 1 and 4 (each within the scatter of the next); then compounds 2 and 3 (each within the scatter of the next).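

In this assay, the kind of ring on the sulfur proves to matter: the step is a number 26.7 percentage points lower from compound 3 to compound 4 (beyond the scatter) and, against the benzoxazole, a number 19.9 percentage points lower from compound 2 to compound 4 (beyond the scatter), while the two aromatic rings had stayed within the scatter of each other. The sulfur link alone therefore does not secure the gain over chloro, as the step of a number 6.2 percentage points higher from compound 1 to compound 4 (within the scatter) shows. Nothing available here explains this difference. Going by these compounds, whether an amine or a carboxylic acid in place of the chloro on the saturated chain carbon would match the aromatic rings remains open.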